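Methyl replaces isopropylamino on a sulfonyl sulfur

A few compounds are considered here, and "the series" means these few. Any claim that something is new, unique, unknown or untested is made for them only; others in the source may bear on it.

In an in vitro ADME assay on microsomes from liver (Homo sapiens) for metabolic stability, read by LC-MS, tested at 1 uM (on this read-out lower numbers stand for slow clearance and higher numbers for fast clearance), compound 1 (`O=C(O)COc1ccc(Cl)cc1C#Cc1ccc(CO)cc1F`) gives < 10 mL.min-1.g-1 as a limit of the assay, not a number. Compound 2 (`CCCS(=O)(=O)c1ccc(F)c(C#Cc2cc(Cl)ccc2OCC(=O)O)c1`) gives 12 mL.min-1.g-1 as a true number, and its sulfonyl sulfur carries no amino group. Compound 3 (`Cc1ccc(S(=O)(=O)NC(C)C)cc1C#Cc1cc(Cl)ccc1OCC(=O)O`) gives < 10 mL.min-1.g-1 as a limit too (the limit of < 10 mL.min-1.g-1 in this assay, at which 2 of the 3 values shown sit). Compound 4 (`Cc1ccc(S(C)(=O)=O)cc1C#Cc1cc(Cl)ccc1OCC(=O)O`) carries methyl in place of isopropylamino on a sulfonyl sulfur. Among the compounds with values here, no measured pair differs in this one place, and compound 2 at 12 mL.min-1.g-1 is the nearest guide, so no step beyond the scatter in this assay is expected. The estimated step runs a step that the limit leaves unreadable from compound 3 to compound 4 by this reckoning. Compound 4 is estimated at 9 mL.min-1.g-1 with a range from 5 mL.min-1.g-1 to 16 mL.min-1.g-1 as the expected spread.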

Compound 4, intrinsic clearance in microsomes: 14 mL.min-1.g-1
Compound 4: middle estimate off by 1.6-fold (0.19 log units), on the low side; the range from low to high includes it.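

In this assay, methyl in place of isopropylamino on the sulfonyl sulfur gives an at least 1.4-fold higher number from compound 3 to compound 4 (0.14 log units; that floor lies within the scatter), so this pair shows no firm change. Compound 4 does give this position a true number to work from. The real size of the step stays hidden, since compound 3 sits at a limit of the assay: the limit of < 10 mL.min-1.g-1 in this assay, at which 2 of the 4 values shown sit.

Still open, as far as these compounds go, is whether the nitrogen or the size of the group matters on this sulfur. A dimethylamino or ethylamino group there would help separate the two.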